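Fluorine moved on the sulfonyl aryl group

The compounds below may be only part of what the source reports. "The series", "measured", "known", "first", "only" and "open" are said of these compounds alone.

Measured so far in an assay on isolated protein for inhibition of malate dehydrogenase, mitochondrial (Sus scrofa), with stated times of 45 min and 30 min; a higher number here means a weaker inhibitor, a lower number a stronger inhibitor:
compound 1 `Cc1ccc(S(=O)(=O)Nc2ccc3oc(-c4ccccc4)nc3c2)cc1` — compound 1 gives only the assay limit, > 63000 nM
compound 2 `O=S(=O)(Nc1ccc2oc(-c3ccccc3)nc2c1)c1cccc(F)c1` — compound 2 gives only the assay limit, > 63000 nM

Going by the values given here, compound 2 stands at a limit in this assay, not at a number, and the same holds for the one other value shown. The step that the two limits leave unreadable from compound 1 to compound 2 cannot be read, since both ends are limits; this is stated by the limit of > 63000 nM in this assay, at which 2 of the 2 values shown sit.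

Compound 3 is `O=S(=O)(Nc1ccc2oc(-c3ccccc3)nc2c1)c1ccccc1F`. The change from compound 2 is 2-fluorophenyl in place of 3-fluorophenyl on a sulfonyl sulfur. No measured step bears on this change with a readable size: the only step shown, from compound 1 to compound 2, is unreadable. The expectation for compound 3 in this assay therefore rests on the fact that both values shown are limits, so compound 3 is expected to remain at a limit as well, with the step that the limit leaves unreadable from compound 2 to compound 3 expected to lie within the scatter. Compound 3 is estimated at 80000 nM, in the range 20000 nM to 300000 nM, with a limit rather than a number expected.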

Compound 3, half-maximal inhibitory concentration: > 63000 nM
Compound 3: only a limit was reported; the forecaster's own chance of this, stated with the estimate: 85%; the middle value lies beyond the limit too.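

In this assay compound 3 gives > 63000 nM, which is a limit and not a number. No step among compound 1, compound 2 and compound 3 can be read, since all three stand at a limit: the limit of > 63000 nM in this assay, at which 3 of the 3 values shown sit.

The compounds shown leave open how the 4-methylphenyl, 3-fluorophenyl and 2-fluorophenyl groups on the sulfonyl sulfur rank against one another in this assay.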